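The source may report more compounds than this note shows. Statements on the series, on what has been measured and on what is new or still open speak of the compounds shown alone.

Three compounds share one core and differ only in the group on a saturated ring carbon. Compound 1 `N#CC1=C(N)N(c2ccc(S(N)(=O)=O)cc2)C2=C(CCCC2)C1c1ccccc1` carries a plain phenyl, and in a functional assay on Ehrlich cells (Mus musculus) for cytotoxicity, read by trypan blue exclusion, with a stated time of 2 h, tested at 10 ug/mL (a lower number here means a weaker effect, a higher number a stronger effect of the compound at the concentration tested), compound 1 gives 5%. Compound 2 `Cc1ccc(C2C(C#N)=C(N)N(c3ccc(S(N)(=O)=O)cc3)C3=C2CCCC3)cc1` carries a 4-methylphenyl, and in this assay compound 2 gives 20%. Compound 3 `N#CC1=C(N)N(c2ccc(S(N)(=O)=O)cc2)C2=C(CCCC2)C1c1ccccc1Cl` carries a 2-chlorophenyl, and in this assay compound 3 gives 0%, the lowest of the three numbers, though its gap to compound 1 stays within the scatter. The step of a number 15 percentage points higher from compound 1 to compound 2 (beyond the scatter) is modest but beyond the scatter; the step of a number 5 percentage points lower from compound 1 to compound 3 (within the scatter) is within it; the step of a number 20 percentage points lower from compound 2 to compound 3 (beyond the scatter) is modest.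

Compound 4 `N#CC1=C(N)N(c2ccc(S(N)(=O)=O)cc2)C2=C(CCCC2)C1c1ccc(Cl)cc1Cl` differs from compound 3 by chloro in place of hydrogen on an aromatic carbon. Among the measured compounds shown here, the only measured step of the same kind is a number 5 percentage points lower from compound 1 to compound 3 (within the scatter), which stayed within the scatter, and the other two steps concern different groups and do not bear on it directly. Compound 4 is therefore expected to sit close to compound 3, with an expected step of a number 3 percentage points higher from compound 3 to compound 4 (within the scatter) and no change beyond the scatter. In this assay compound 4 is estimated at 3%, with a range from 0% to 15%.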

Compound 4, a percentage reported as activity, at one concentration (the size of the read-out at that concentration, not a potency): 0%
The estimate for compound 4 lay 3 percentage points above the measured number, and the stated range covers the measured number.
By their numbers in this assay, from the lowest: compounds 3, 4 and 1 (each within the scatter of the next); then compound 2.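

In this assay the second chloro group, meta to a chloro group and para to a large group, gives no change at the digits printed from compound 3 to compound 4 (within the scatter) and so adds nothing that this read-out can register on top of the 2-chlorophenyl group. The 2,4-dichlorophenyl group therefore falls on the same side of the series as the 2-chlorophenyl group, with a number 20 percentage points lower from compound 2 to compound 4 (beyond the scatter) and with a number 5 percentage points lower from compound 1 to compound 4 (within the scatter) so that the only substituent shown to lift the number beyond the scatter remains the methyl group of compound 2, while neither chloro pattern separates from plain phenyl. Nothing available here accounts for this flat result.

Because compound 3 already stands at 0% the added chloro group could show no further loss in this read-out, so the compounds shown leave open whether it is truly without effect or only unseen at this one concentration. They also leave open whether a 4-chlorophenyl group without the other chloro group would follow the 4-methylphenyl group of compound 2 or the chlorinated compounds, and whether a methoxy group, a hydroxyl group or an amine in that place would raise the number further.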